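Dipropylamino Variant of a Corticotropin Receptor Ligand

This account rests on a few compounds, and the source may have more. Where it says the series, first, only, none or still open, it means among the compounds named here.

Going by the values given here, of the two compounds measured so far, compound 2 `CCCC(C)Nc1nc(C)nc2c(-c3c(C)cc(OC)cc3OC)c(C)nn12` gives 2.14 nM in an assay on cell membranes for displacement of a labelled ligand from corticotropin-releasing factor receptor 1 (Rattus norvegicus) (a lower number here means a stronger inhibitor, a higher number a weaker inhibitor), and compound 1 `CCN(CCC#N)c1nc(C)nc2c(-c3c(C)cc(OC)cc3OC)c(C)nn12` gives 2.48 nM in this assay, a pair that the step of a 1.2-fold lower number from compound 1 to compound 2 (0.06 log units; within the scatter) shows to sit within the scatter. That step exchanged one amine for another on the shared core. Compound 3 `CCCN(CCC)c1nc(C)nc2c(-c3c(C)cc(OC)cc3OC)c(C)nn12` carries dipropylamino in place of (1-methylbutyl)amino on an aromatic carbon, again an exchange of the amine at that carbon. Among the compounds with values here, since the only comparable step, a 1.2-fold lower number from compound 1 to compound 2 (0.06 log units; within the scatter), stayed within the scatter, no shift beyond it is expected in this assay. Compound 3 is therefore estimated at 2.5 nM, within 0.8 nM to 8 nM, a step of a 1.2-fold higher number from compound 2 to compound 3 (0.07 log units; within the scatter).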

Compound 3, half-maximal inhibitory concentration: 3.72 nM
The estimate for compound 3 lay 1.5-fold (0.17 log units) below the measured number; the range from low to high includes it.
By their numbers in this assay, from the lowest: compounds 2, 1 and 3 (each within the scatter of the next).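

In this assay, dipropylamino gives a 1.7-fold higher number from compound 2 to compound 3 (0.24 log units; within the scatter) and a 1.5-fold higher number from compound 1 to compound 3 (0.18 log units; within the scatter). At this aromatic carbon, then, the hydrogen-bond donor of (1-methylbutyl)amino and the nitrile of (2-cyanoethyl)(ethyl)amino can both be absent without a shift beyond the scatter. No measurement shown explains why these numbers lie so close. Still open, as far as these compounds go, is whether a ring amine such as morpholine, or a shorter chain such as dimethylamino, would stay within the scatter at this carbon.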